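Fluorophenyl hydrazone variant in the triazolopyrimidine series

The source may hold more compounds than are shown below. What is called first, only, known or untested is meant among the compounds shown, and "the series" means these compounds.

Among the measured compounds shown here, compound 1 `CCCSc1nc(N/N=C(\C)c2ccc(O)cc2)c2nnn(Cc3ccccc3)c2n1` is the weakest of the three measured members of this set: in a functional assay on MGC-803 cells (Homo sapiens) for antiproliferative activity, read by MTT assay, with a stated time of 72 h (a lower number here means a stronger inhibitor, a higher number a weaker inhibitor), compound 1 gives 16700 nM. Compound 2 `C#CCSc1nc(N/N=C/c2c(O)ccc3ccccc23)c2nnn(Cc3ccccc3)c2n1` gives 10500 nM, which lies within the scatter of compound 1. For the measured compounds named here, compound 3 `COc1cc(/C=N/Nc2nc(SCc3ccccc3)nc3c2nnn3Cc2ccccc2)cc(OC)c1OC` gives 1320 nM, a gap from compound 1 that is well beyond the scatter, and compound 3 is the only member clearly separated from the others.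

Compound 4 `CCCSc1nc(N/N=C/c2ccccc2F)c2nnn(Cc3ccccc3)c2n1` is reached from compound 1 by a single exchange on the hydrazone side: a group of 9 heavy atoms (7 carbon, 1 nitrogen, 1 fluorine; one six-membered aromatic ring of carbon only) in place of a group of 10 heavy atoms (8 carbon, 1 nitrogen, 1 oxygen; one six-membered aromatic ring of carbon only), on a nitrogen on an aromatic ring. Going by the values given here, no step between measured compounds isolates this kind of exchange, so the direction can only be inferred loosely from the spread of the three values. The two measured compounds whose hydrazones carry one hydrogen on the double-bond carbon, compound 2 and compound 3, both sit below compound 1, though they also differ from compound 1 in the thioether chain.

Compound 4 is therefore expected to give a modestly lower number than compound 1, an estimated step of a 2.1-fold lower number from compound 1 to compound 4 (0.32 log units; beyond the scatter). The estimate for compound 4 is 8000 nM, within 2500 nM to 25000 nM.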

Compound 4, half-maximal inhibitory concentration: > 64000 nM
Compound 4 was reported as a limit; the forecaster's own chance of this, stated with the estimate: 10%; at least 8.0-fold (0.90 log units) between middle value and limit.
By their numbers in this assay, from the lowest: compound 3; then compounds 2 and 1 (each within the scatter of the next). At a limit, above all of these: compound 4.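

In this assay, the group on the nitrogen on an aromatic ring proves sensitive to change: with the propyl thioether kept, the exchange gives an at least 3.8-fold higher number from compound 1 to compound 4 (0.58 log units; beyond the scatter). Compound 4 is reported only as a limit, > 64000 nM, so this step has a lower bound and no measured size. It is the only step shown that changes one place, and the limit stands alone among the values: the limit of > 64000 nM in this assay, at which 1 of the 4 values shown sits.

The exchange alters the group in more than one way, taking it from 1 hydrogen-bond donor to 0 and from 8 carbons to 7 while swapping oxygen for fluorine, and the step does not separate these changes. Going by these compounds, whether an amine or a carboxylic acid on this ring would return a number near that of compound 1 remains open.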